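A few compounds are considered here, and "the series" means these few. Any claim that something is new, unique, unknown or untested is made for them only; others in the source may bear on it.

Compound 1 `COc1cc2c(Oc3ccc(NC(=O)c4cn(-c5cc(C)ccc5C)cn4)cc3F)ccnc2cc1OCCCN1CCN(C)CC1`, in a functional assay on HT-29 cells (Homo sapiens) for cytotoxicity, read by MTT assay, with a stated time of 72 h (a higher number here means a weaker inhibitor, a lower number a stronger inhibitor), compound 1 gives 470 nM. Compound 2 `COc1cc2c(Oc3ccc(NC(=O)c4cn(-c5ccccc5OC)cn4)cc3F)ccnc2cc1OCCCN1CCCCC1`, compound 2 gives 100 nM. Compound 3 `COc1cc2c(Oc3ccc(NC(=O)c4cn(-c5ccccc5OC(F)(F)F)cn4)cc3F)ccnc2cc1OCCCN1CCCCC1`, compound 3 gives 250 nM.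

Compound 3 sits second highest of the three numbers in this assay: its gap to compound 1 stays within the scatter, while the step of a 2.5-fold higher number from compound 2 to compound 3 (0.40 log units; beyond the scatter) lies beyond it. Compound 4 `COc1cc2c(Oc3ccc(NC(=O)c4cn(-c5cc(C)ccc5C)cn4)cc3F)ccnc2cc1OCCCN1CCCCC1` differs from compound 3 by 2,5-dimethylphenyl in place of 2-(trifluoromethoxy)phenyl on an aromatic nitrogen. Among the measured compounds shown here, the only measured step at this position is a 2.5-fold higher number from compound 2 to compound 3 (0.40 log units; beyond the scatter), a modest one. Compound 1 carries the same 2,5-dimethylphenyl as compound 4 but a different amine at the other end, so its value is only a loose guide. The step of a 1.2-fold higher number from compound 3 to compound 4 (0.08 log units; within the scatter) is therefore expected to be small. Compound 4 is estimated at 300 nM, within 100 nM to 900 nM.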

Compound 4, half-maximal inhibitory concentration: 580 nM
Estimate against measurement, compound 4: 1.9-fold (0.29 log units) below, within the range that was stated.
By their numbers in this assay, from the lowest: compound 2; then compounds 3, 1 and 4 (each within the scatter of the next, the first and the last beyond it).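

In this assay, 2,5-dimethylphenyl on the aromatic nitrogen gives a 2.3-fold higher number from compound 3 to compound 4 (0.37 log units; beyond the scatter) and a 5.8-fold higher number from compound 2 to compound 4 (0.76 log units; beyond the scatter), so this position separates all three groups, with 2-methoxyphenyl carrying the lowest number. Exchanging 4-methylpiperazin-1-yl for piperidin-1-yl at the other end gives a 1.2-fold higher number from compound 1 to compound 4 (0.09 log units; within the scatter), so with 2,5-dimethylphenyl in place that change has no readable effect. Nothing at hand explains these differences. Going by these compounds, it remains open where an unsubstituted phenyl or a 2-chlorophenyl would fall at this position, and whether 4-methylpiperazin-1-yl would match piperidin-1-yl alongside 2-methoxyphenyl.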